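A few compounds are considered here, and "the series" means these few. Any claim that something is new, unique, unknown or untested is made for them only; others in the source may bear on it.

Of the compounds shown here, three built on one shared core have been tested in a functional assay on the whole organism (strain Wistar) for inhibition, with Rattus norvegicus as the target, read by paw edema, with stated times of 60 min and 1 h, at a dose of 100 mg/kg by the oral route; on this read-out lower numbers stand for less inhibition and higher numbers for more inhibition at the one dose given (going by the name of the read-out). Compound 1 `COc1cc2c(cc1OC)C(CC(=O)NC(C)C)CC2` gives 31.3%, compound 2 `COc1cc2c(cc1OC)C(CC(=O)NC(C)(C)C)CC2` gives 31.3%, and compound 3 `CCCCCNC(=O)CC1CCc2cc(OC)c(OC)cc21` gives 34.4%. Compound 2 differs from compound 1 by methyl in place of hydrogen on a saturated chain carbon bound to an amide-type nitrogen and two saturated chain carbons, and that step reads no change at the digits printed from compound 1 to compound 2 (within the scatter). Compound 4 `CCCCCCNC(=O)CC1CCc2cc(OC)c(OC)cc21` has not yet been measured; it differs from compound 3 by methyl in place of hydrogen on a saturated chain carbon, five bonds along the chain from an amide-type nitrogen. The cores of compound 1 and compound 3 differ by pentyl in place of isopropyl on an amide-type nitrogen. The two places are not the same word for word: in one the carbon is bound to an amide-type nitrogen and two saturated chain carbons, in the other it lies five bonds along the chain from an amide-type nitrogen, so this is the same kind of change, not the same one. Because no change at the digits printed from compound 1 to compound 2 (within the scatter), the like step in this assay is expected to be a number 0.4 percentage points lower from compound 3 to compound 4 (within the scatter). Compound 4 is therefore estimated at 34%, with a likely range from 24% to 44%.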

Compound 4, a percentage reported as inhibition, in the whole organism at one dose (the size of the read-out at that dose, not a potency): 47.6%
Beside the measured number, compound 4's estimate is 13.6 percentage points below it; measured number above the stated range.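

In this assay methyl in place of hydrogen on a saturated chain carbon, five bonds along the chain from an amide-type nitrogen, reads a number 13.2 percentage points higher from compound 3 to compound 4 (beyond the scatter) and hexyl in place of tert-butyl reads a number 16.3 percentage points higher from compound 2 to compound 4 (beyond the scatter) while hexyl in place of isopropyl reads a number 16.3 percentage points higher from compound 1 to compound 4 (beyond the scatter) on that nitrogen. Set beside each other, the two methyl steps do not differ beyond the scatter: the same change on two cores in this assay, no change at the digits printed (within the scatter) from compound 1 to compound 2 and a number 13.2 percentage points higher (beyond the scatter) from compound 3 to compound 4, 13.2 percentage points apart, within the scatter of two such steps. For the compounds shown here, this does not show that the methyl step carries over unchanged from one core to another, nor that it fails to, since only one pair stands on each side and the two places are not the same.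

Still open, as far as these compounds go, is whether a longer chain such as heptyl on the amide-type nitrogen would give a higher number. How a chain carrying an amine or a carboxylic acid would read is open too.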